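Swapping the pentyl for isopropyl on two related cores

The compounds below may be only part of what the source reports. "The series", "measured", "known", "first", "only" and "open" are said of these compounds alone.

Compound 1 `CCCCCn1nc2oc(=O)cc(C)c2c1C` and compound 2 `Cc1cc(=O)oc2nn(C(C)C)c(C)c12` share one core. In a functional assay on the whole organism with Mus musculus as the target, in the writhing test (on this read-out lower numbers stand for an effect already at smaller amounts and higher numbers for an effect only at larger amounts of compound), compound 1 gives 60.6 mg/kg, while compound 2 gives 35.3 mg/kg. The change between them, (isopropyl in place of pentyl on an aromatic nitrogen), produced a 1.7-fold lower number from compound 1 to compound 2 (0.23 log units; within the scatter). Compound 3 `CCCCCn1nc(C)c2c(C)cc(=O)oc21` has the same atoms as compound 1 joined differently, and the difference between the two cores is not broken down here. In this assay compound 3 reaches only a limit, > 100 mg/kg, which is the limit of > 100 mg/kg in this assay, at which 1 of the 3 values shown sits. Compound 4 `Cc1cc(=O)oc2c1c(C)nn2C(C)C` differs from compound 3 by isopropyl in place of pentyl on an aromatic nitrogen; this is the same kind of change as before, although here the isopropyl sits two ring bonds from the ring atom that bears a methyl group rather than next to it. For compound 4 a step of an at least 1.1-fold lower number from compound 3 to compound 4 (0.04 log units; that floor lies within the scatter) is expected, resting on a 1.7-fold lower number from compound 1 to compound 2 (0.23 log units; within the scatter). Compound 4 is therefore estimated at 90 mg/kg, in a range from 40 mg/kg to 200 mg/kg.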

Compound 4, dose for half-maximal effect: > 100 mg/kg
Compound 4: no number, only a limit; the forecaster's own chance of this, stated with the estimate: 45%; at least 1.1-fold (0.04 log units) between middle value and limit.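

Compound 3 and compound 4 both reach only a limit, so no step between them can be read: the limit of > 100 mg/kg in this assay, at which 2 of the 4 values shown sit.

The compounds shown leave open whether isopropyl in place of pentyl on an aromatic nitrogen changes the effect at all on the core of compound 3.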